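Swapping the aryl group on the shared core

A few compounds are considered here, and "the series" means these few. Any claim that something is new, unique, unknown or untested is made for them only; others in the source may bear on it.

Of the compounds shown here, three sharing one core have been measured in a functional assay on MDA-MB-231 cells (Homo sapiens) for cytotoxicity, read by MTT assay, with a stated time of 72 h; on this read-out lower numbers stand for stronger inhibition and higher numbers for weaker inhibition. Compound 3 `FC(F)(F)c1ccc(CSc2nc(Nc3ccc(Cl)cc3)c3ccccc3n2)cc1` gives 15100 nM and carries the lowest number of the two numbers recorded, though compound 2 `FC(F)(F)c1ccc(CSc2nc(Nc3cccc(Br)c3)c3ccccc3n2)cc1` with 22100 nM sits within the scatter of it, as a 1.5-fold lower number from compound 2 to compound 3 (0.17 log units; within the scatter) shows. Compound 1 `CCOc1ccccc1Nc1nc(SCc2ccc(C(F)(F)F)cc2)nc2ccccc12` reaches only a limit of the assay, > 50000 nM, as noted under (the limit of > 50000 nM in this assay, at which 1 of the 3 values shown sits). The steps of an at least 2.2-fold lower number from compound 1 to compound 2 (0.35 log units; beyond the scatter) and an at least 3.3-fold lower number from compound 1 to compound 3 (0.51 log units; beyond the scatter) are both beyond the scatter.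

Compound 4 `COc1ccc(Nc2nc(SCc3ccc(C(F)(F)F)cc3)nc3ccccc23)c(OC)c1` differs from compound 3 by 2,4-dimethoxyphenyl in place of 4-chlorophenyl on a nitrogen on an aromatic ring. Going by the values given here, no measured step makes exactly this change, but the entering ring carries oxygen-bearing groups, as does the ring of compound 1, and the two steps away from compound 1 both lowered the number. The expected change is therefore an upward one, a 2.6-fold higher number from compound 3 to compound 4 (0.42 log units; beyond the scatter), in this assay. The estimate for compound 4 is 40000 nM, with a range from 15000 nM to 100000 nM, and a real chance that only a limit is reported.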

Compound 4, half-maximal inhibitory concentration: > 50000 nM
Compound 4 gave a limit, no number (the forecaster's own chance of this, stated with the estimate: 45%); middle value at least 1.2-fold (0.09 log units) from the limit.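

In this assay compound 4 stays at a limit rather than a number, the same limit as compound 1: the limit of > 50000 nM in this assay, at which 2 of the 4 values shown sit. Replacing the ring on the nitrogen gives an at least 3.3-fold higher number from compound 3 to compound 4 (0.51 log units; beyond the scatter) and also an at least 2.2-fold higher number from compound 2 to compound 4 (0.35 log units; beyond the scatter), so this position responds to a change of ring in the upward direction as well as the downward one. Among these four compounds, the two rings with oxygen-bearing groups sit at the limit and the rings with chlorine or bromine give numbers, with no compound going against this, while the step between compound 1 and compound 4 cannot be read, as both are limits.

As far as these compounds go, whether the oxygen atoms themselves matter remains open. A phenyl ring carrying a methyl group, an amine or a carboxylic acid on this nitrogen could help separate the oxygen from the other features of these rings.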